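The source may hold more compounds than are shown below. What is called first, only, known or untested is meant among the compounds shown, and "the series" means these compounds.

Among the measured compounds shown here, in a functional assay on A-375 cells (Homo sapiens) for activation, with a stated time of 3 days (a lower number here means that less compound is needed, a higher number that more compound is needed for the effect), compound 1 `O=C(Nc1ccc(-c2cscn2)cc1)C1CCCN(Cc2ccc(F)c(F)c2)C1` gives 1240 nM, the only numeric value so far. Compound 2 `O=C(Nc1ccc(-c2cscn2)cc1)C1CN(Cc2ccc(F)c(F)c2)C1` gives > 20000 nM, which is a limit and not a number. The next change leads to compound 3 `O=C(Nc1ccc(-c2cscn2)cc1)C1CCCN(C(=O)c2ccc(F)c(F)c2)C1`: (3,4-difluorophenyl)carbonyl in place of 3,4-difluorobenzyl on an amine nitrogen in a ring, ((3,4-difluorophenyl)carbonyl in place of 3,4-difluorobenzyl on an amine nitrogen in a ring). For the measured compounds named here, no measured pair shows this kind of change, so the expectation is loose: a moderate rise in the number in this assay. The expected step is a 2.8-fold higher number from compound 1 to compound 3 (0.45 log units; beyond the scatter). Compound 3 is estimated at 3500 nM, with an expected range of 900 nM to 15000 nM.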

Compound 3, half-maximal effective concentration: > 20000 nM
Compound 3 was reported as a limit; the forecaster's own chance of this, stated with the estimate: 20%; at least 5.7-fold (0.75 log units) between middle value and limit.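

Until now, only 3,4-difluorobenzyl stood on this amine nitrogen in a ring. With (3,4-difluorophenyl)carbonyl in its place, the series shows an at least 16-fold higher number from compound 1 to compound 3 (1.20 log units; beyond the scatter) in this assay and this position proves highly sensitive to the change. Compound 3 gives > 20000 nM as a limit and not a number, so the step is only a bound: the limit of > 20000 nM in this assay, at which 2 of the 3 values shown sit.

Still open, as far as these compounds go, is how far compound 3 actually lies from compound 1. Also open, from the compounds shown here alone, is whether a phenethyl group or a 3,4-difluorophenylsulfonyl group on this nitrogen would give a numeric value.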